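Methyl on the ring nitrogen of the shared core

The compounds below may be only part of what the source reports. "The series", "measured", "known", "first", "only" and "open" are said of these compounds alone.

Measured so far:
- compound 1, `CN1CCN(c2nc(-c3cccc(O)c3)nc3c2ncn3C)CC1`: 27.1%
- compound 2, `CN1CCN(c2nc(-c3ccc(Cl)c(Cl)c3)nc3[nH]cnc23)CC1`: > 80%
- compound 3, `Clc1ccc(-c2nc(N3CCCCC3)c3nc[nH]c3n2)cc1Cl`: 24.1%

Going by the values given here, in an assay on cells for displacement of a labelled ligand from adenosine receptor A1 (Homo sapiens), read by scintillation counting and radioligand binding, with a stated time of 60 min, tested at 10 uM (a higher number here means more inhibition at the concentration tested (going by the name of the read-out), a lower number less inhibition), compound 2 gives > 80%, which is a limit of the assay and not a number; it is the one value among the three that sits at the limit of > 80% in this assay, at which 1 of the 3 values shown sits. Compound 3 gives 24.1% in this assay, and the change in the amine leaves a number at least 55.9 percentage points lower from compound 2 to compound 3 (beyond the scatter). Among the compounds with values here, compound 1 gives 27.1% in this assay; it carries the methyl on the ring nitrogen but differs from compound 2 in two places, so its value alone shows only that a methylated analogue of this core can sit low.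

Compound 4, `CN1CCN(c2nc(-c3ccc(Cl)c(Cl)c3)nc3c2ncn3C)CC1`, differs from compound 2 by methyl in place of hydrogen on an aromatic nitrogen. Within the data shown here, no measured step in this assay alters that ring nitrogen alone, so no size or direction of step can be taken from the measured pairs. Compound 4 is therefore estimated with wide bounds at 55%, between 25% and 85%, which would mean an expected step of a number at least 25 percentage points lower from compound 2 to compound 4 (beyond the scatter).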

Compound 4, a percentage reported as inhibition, at one concentration (the size of the read-out at that concentration, not a potency): 65.2%
The estimate for compound 4 lay 10.2 percentage points below the measured number; the range from low to high includes it.
By their numbers in this assay, from the lowest: compounds 3 and 1 (each within the scatter of the next); then compound 4. At a limit, above all of these: compound 2.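

Methyl in place of hydrogen on an aromatic nitrogen of the shared core is the only change here that isolates this position, and in this assay it leaves a number at least 14.8 percentage points lower from compound 2 to compound 4 (beyond the scatter). With the ring nitrogen methylated in both compounds, 3,4-dichlorophenyl in place of 3-hydroxyphenyl gives a number 38.1 percentage points higher from compound 1 to compound 4 (beyond the scatter), so the methyl alone does not account for the low value of compound 1. The value of compound 2 is a limit of the assay and not a number: the limit of > 80% in this assay, at which 1 of the 4 values shown sits.

As far as these compounds go, the full size of the methyl step remains open, as does whether it holds with piperidin-1-yl in place of 4-methylpiperazin-1-yl. Also open, from the compounds shown here alone, is how ethyl, or a longer chain ending in an amine or a carboxylic acid, would read on the same ring nitrogen.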